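Working notes: from phenyl to benzyl in the series

The source may hold more compounds than are shown below. What is called first, only, known or untested is meant among the compounds shown, and "the series" means these compounds.

Measured so far in a functional assay on A549 cells (Homo sapiens) for inhibition; on this read-out lower numbers stand for stronger inhibition and higher numbers for weaker inhibition
- compound 1 `CCOC(=O)Nc1nc(=O)n(C2O[C@H](C(=O)O)[C@@H](O)[C@H]2O)cc1F` gives 0.49 ug/mL
- compound 2 `C=CCOC(=O)Nc1nc(=O)n(C2O[C@H](C(=O)O)[C@@H](O)[C@H]2O)cc1F` gives 0.04 ug/mL
- compound 3 `O=C(Nc1nc(=O)n(C2O[C@H](C(=O)O)[C@@H](O)[C@H]2O)cc1F)Oc1ccccc1` gives 0.55 ug/mL

Compound 3 stands level with compound 1, with a 1.1-fold higher number from compound 1 to compound 3 (0.05 log units; within the scatter) inside the scatter. Compound 2 stands well apart, as a 14-fold higher number from compound 2 to compound 3 (1.14 log units; beyond the scatter) shows.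

Compound 4 `O=C(Nc1nc(=O)n(C2O[C@H](C(=O)O)[C@@H](O)[C@H]2O)cc1F)OCc1ccccc1` has not yet been measured. The change is benzyl in place of phenyl on an oxygen next to a carbonyl group (in words, benzyl in place of phenyl on an oxygen next to a carbonyl group).

Among the compounds with values here, no measured step makes this exact exchange, so the evidence is indirect. Within the data shown here, two steps bear on it. The exchange of ethyl for phenyl gave a 1.1-fold higher number from compound 1 to compound 3 (0.05 log units; within the scatter) and so moved nothing beyond the scatter. The exchange of ethyl for allyl gave a 12-fold lower number from compound 1 to compound 2 (1.09 log units; beyond the scatter) and so shows that one change in this group can be large. These two steps point in different directions, and benzyl has not been tested in this assay at all.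

The expected result is a 1.8-fold lower number from compound 3 to compound 4 (0.26 log units; within the scatter) and no step beyond the scatter is expected, though a lower number remains possible. The estimated value for compound 4 is 0.3 ug/mL with an expected range from 0.06 ug/mL to 1 ug/mL in this estimate.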

Compound 4, half-maximal inhibitory concentration: 0.37 ug/mL
Compound 4: middle estimate off by 1.2-fold (0.09 log units), on the low side; measured number inside the range.
By their numbers in this assay, from the lowest: compound 2; then compounds 4, 1 and 3 (each within the scatter of the next).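

In this assay, benzyl in place of phenyl on an oxygen next to a carbonyl group gives a 1.5-fold lower number from compound 3 to compound 4 (0.17 log units; within the scatter), so going from phenoxy to benzyloxy does not move the read-out beyond the scatter, and the step against ethyl, a 1.3-fold lower number from compound 1 to compound 4 (0.12 log units; within the scatter), likewise stays inside it. Compounds 1, 3 and 4 therefore sit level, with ethyl, phenyl and benzyl indistinguishable at this position, and compound 2 alone goes against that flat picture. The new comparison also shows that a phenyl on the saturated chain carbon does not match the vinyl there, with a 9.3-fold higher number from compound 2 to compound 4 (0.97 log units; beyond the scatter), so an unsaturated group on that carbon does not by itself reproduce the result for compound 2, and no measurement at hand accounts for this difference.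

The compounds shown leave open whether a propargyl group or a longer alkenyl chain such as butenyl on this oxygen would stay with compound 2 or fall back to the level of compounds 1, 3 and 4. They also leave open whether a methoxy or fluoro substituent on the benzyl ring would shift the read-out at all.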